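This account rests on a few compounds, and the source may have more. Where it says the series, first, only, none or still open, it means among the compounds named here.

Compound 1, `N#C/N=C(/NCCCCNc1nc(N)n[nH]1)NCCSc1ccccc1`, gives < 5 in a functional assay on Sf9 cells for antagonist activity at histamine H2 receptor (Homo sapiens), read by scintillation counting and GTPgammaS binding, with a stated time of 90 min; a higher number here means a more potent compound, by a factor of ten per unit of this negative logarithm, a lower number a less potent compound.
Compound 2, `N#C/N=C(/NCCCSc1nc(N)n[nH]1)NCCSc1ccccc1`, gives < 5 in this assay.
Compound 3, `N#C/N=C(/NCCCCNc1ccccn1)NCCSc1ccccc1`, gives < 5 in this assay.

Each of these three values is a limit of this assay and not a number. Compound 2 therefore stands at the limit, with nothing to separate it from its neighbours: the limit of < 5 in this assay, at which 3 of the 3 values shown sit. The three steps among the measured compounds share this fate. The change a step that the two limits leave unreadable from compound 1 to compound 2 cannot be sized, nor can a step that the two limits leave unreadable from compound 1 to compound 3, nor a step that the two limits leave unreadable from compound 2 to compound 3.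

The piece now follows the step from compound 2 to compound 4, `N#C/N=C(/NCCNc1nccc(N)n1)NCCSc1ccccc1`. The change is (4-aminopyrimidin-2-yl)amino in place of ((3-amino-1H-1,2,4-triazol-5-yl)sulfanyl)methyl on a saturated chain carbon, two bonds along the chain from an amine nitrogen. Of the measured steps, the one that bears on it most closely is a step that the two limits leave unreadable from compound 1 to compound 2, which touches the same (3-amino-1H-1,2,4-triazol-5-yl)sulfanyl group, and a step that the two limits leave unreadable from compound 2 to compound 3, which also removes that group; both are unreadable, so they give no direction and no size for the expected step. With nothing to lean on, compound 4 is expected to sit near 5 in this assay, within 4 to 6, and the step from compound 2 is estimated at a number no lower from compound 2 to compound 4 (the limit leaves the size open), with a fair chance that only a limit is reported again.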

Compound 4, negative logarithm of the antagonist equilibrium constant: < 5
Compound 4 was reported as a limit (the forecaster's own chance of this, stated with the estimate: 65%); the middle value lies on the limit itself.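

Compound 4 gives < 5 in this assay, which is a limit and not a number. The step from compound 2 to compound 4 therefore cannot be read, since both compounds stand at the same limit: the limit of < 5 in this assay, at which 4 of the 4 values shown sit.

The compounds shown leave open the actual potency of all four compounds, and so whether any of these changes of group alters it.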